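A few compounds are considered here, and "the series" means these few. Any claim that something is new, unique, unknown or untested is made for them only; others in the source may bear on it.

Working notes on the series. The shared core is seen in compound 1 `CC(C)[C@@H]1CC[C@@H](C)C[C@@]12N(C)C(=O)[C@@H]1[C@H]3C(=O)NC(=O)[C@H]3ON12`, compound 2 `CC(C)[C@@H]1CC[C@@H](C)C[C@@]12N(C)C(=O)[C@@H]1[C@H]3C(=O)N(C)C(=O)[C@H]3ON12` and compound 3 `COc1ccc(N2C(=O)[C@H]3[C@H](ON4[C@@H]3C(=O)N(C)[C@@]43C[C@H](C)CC[C@H]3C(C)C)C2=O)cc1`. In a functional assay, read by spectrophotometry, with a stated time of 2 h, tested at 2 mg/mL (a lower number here means a weaker effect, a higher number a stronger effect of the compound at the concentration tested), compound 1 gives 57.2%, compound 2 gives 59.9% and compound 3 gives 68.9%, the highest of the three numbers. The measured steps are a number 2.7 percentage points higher from compound 1 to compound 2 (within the scatter), a number 11.7 percentage points higher from compound 1 to compound 3 (beyond the scatter) and a number 9 percentage points higher from compound 2 to compound 3 (within the scatter). Compound 4 `Cc1ccc(N2C(=O)[C@H]3[C@H](ON4[C@@H]3C(=O)N(C)[C@@]43C[C@H](C)CC[C@H]3C(C)C)C2=O)c(C)c1` differs from compound 3 by 2,4-dimethylphenyl in place of 4-methoxyphenyl on an amide-type nitrogen in a ring. Going by the values given here, no measured step exchanges one aryl group for another on this nitrogen; the two steps that place an aryl group there are modest or within the scatter. Because compound 3 gives 68.9%, the expected step in this assay is a number 1.9 percentage points lower from compound 3 to compound 4 (within the scatter), nothing beyond the scatter. Compound 4 is expected at 67%, within 54% to 80%.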

Compound 4, a percentage reported as activity, at one concentration (the size of the read-out at that concentration, not a potency): 79.4%
Estimate against measurement, compound 4: 12.4 percentage points below; measured number inside the range.
By their numbers in this assay, from the lowest: compounds 1, 2 and 3 (each within the scatter of the next, the first and the last beyond it); then compound 4.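

On the amide-type nitrogen in a ring, the choice of aryl group now counts: in this assay there is a number 10.5 percentage points higher from compound 3 to compound 4 (beyond the scatter) on exchanging 4-methoxyphenyl for 2,4-dimethylphenyl. The gap to the methyl compound also clears the scatter, with a number 19.5 percentage points higher from compound 2 to compound 4 (beyond the scatter) where 4-methoxyphenyl did not, and the step from the amide hydrogen widens to a number 22.2 percentage points higher from compound 1 to compound 4 (beyond the scatter) in this series. No measurement at hand bears on the reason for these steps. On these data alone, whether one methyl group alone would carry the step stays open, and so does the outcome with unsubstituted phenyl. A phenyl bearing an amine or a carboxylic acid is equally untested among the compounds shown.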